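The source may report more compounds than this note shows. Statements on the series, on what has been measured and on what is new or still open speak of the compounds shown alone.

Working notes on the series. Within the data shown here, compound 2 `COc1cc2c(Oc3ccc(NC(=O)c4cc(-c5ccc(F)cc5)ccn4)cc3F)ccnc2cc1OCCCN1CCCC1` has the lowest number of the two measured so far in a functional assay on MKN-45 cells (Homo sapiens) for cytotoxicity, read by MTT assay, with a stated time of 72 h (a higher number here means a weaker inhibitor, a lower number a stronger inhibitor), giving 350 nM, while compound 1 `COc1ccc(-c2ccnc(C(=O)Nc3ccc(Oc4ccnc5cc(OCCCN6CCCCC6)c(OC)cc45)c(F)c3)c2)cc1` gives 570 nM, a gap that stays within the scatter. Compound 3 `COc1ccc(-c2ccnc(C(=O)Nc3ccc(Oc4ccnc5cc(OCCCN6CCCC6)c(OC)cc45)c(F)c3)c2)cc1` is reached from compound 2 by methoxy in place of fluoro on an aromatic carbon. Among the measured compounds shown here, no measured pair shows this step on its own, so no size is fixed for it; the expectation is for no change beyond the scatter, leaning toward a slightly higher number, since compound 1, which carries the same methoxyphenyl, gives 570 nM. For compound 3 the estimate in this assay is 500 nM, between 250 nM and 1000 nM, a step of a 1.4-fold higher number from compound 2 to compound 3 (0.15 log units; within the scatter).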

Compound 3, half-maximal inhibitory concentration: 150 nM
Compound 3: the middle estimate sits 3.3-fold (0.52 log units) above what was measured; measured number outside the range, below it.
By their numbers in this assay, from the lowest: compound 3; then compounds 2 and 1 (each within the scatter of the next).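

In this assay, 4-methoxyphenyl in place of 4-fluorophenyl, with pyrrolidin-1-yl held fixed, gives a 2.3-fold lower number from compound 2 to compound 3 (0.37 log units; beyond the scatter) and so shows that this position responds to the change. With 4-methoxyphenyl held fixed, pyrrolidin-1-yl in place of piperidin-1-yl gives a 3.8-fold lower number from compound 1 to compound 3 (0.58 log units; beyond the scatter) and so shows that the end of the chain also matters. Nothing at hand bears on why either step occurs.

As far as these compounds go, whether the methoxy step holds with piperidin-1-yl on the chain stays open. So does how a hydroxyl or dimethylamino group on the phenyl, or a morpholine at the chain end, would read.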